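This account rests on a few compounds, and the source may have more. Where it says the series, first, only, none or still open, it means among the compounds named here.

Measured compounds and their values in the cytotoxicity test:

compound 1, `COc1cc(-c2cc(/C=C/C(=O)c3ccc(N)cc3)[nH]n2)cc(OC)c1OC`: -79%
compound 2, `COc1ccc(-c2cc(/C=C/C(=O)c3ccc(N)cc3)[nH]n2)cc1OC`: -98%
compound 3, `COc1cc(C(=O)/C=C/c2cc(-c3cc(OC)c(OC)c(OC)c3)n[nH]2)cc(OC)c1OC`: -81%

All three were tested in a functional assay on KM12 cells (Homo sapiens) for cytotoxicity, read by sulforhodamine B assay, with a stated time of 48 h, tested at 100 uM; a lower number here means a stronger effect, a higher number a weaker effect of the compound at the concentration tested. Compound 1 gives -79%, compound 2 gives -98%, and compound 3 gives -81%.

Compound 1 and compound 2 differ in one place: hydrogen in place of methoxy on an aromatic carbon. This change made a step of a number 19 percentage points lower from compound 1 to compound 2 (beyond the scatter). Compound 3 is built on a different core from compound 1; the difference between the two cores is not broken down here. The values of compound 3 and compound 1 lie within the scatter of each other, whereas the value of compound 2 is lower than that of compound 3 by more than the scatter.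

Compound 4, `COc1ccc(-c2cc(/C=C/C(=O)c3cc(OC)c(OC)c(OC)c3)[nH]n2)cc1OC`, has not yet been measured. It differs from compound 3 in one place: hydrogen in place of methoxy on an aromatic carbon. The surroundings of the place are described in the same words as for the change from compound 1 to compound 2, so this is the same change made on the core of compound 3.

Because that change gave a number 19 percentage points lower from compound 1 to compound 2 (beyond the scatter), and the value of compound 3 is -81%, the expected step for compound 4 is a number 14 percentage points lower from compound 3 to compound 4 (beyond the scatter). Compound 4 is thus estimated at -95% in this assay. The lower end expected for compound 4 is -100%. The upper end expected for compound 4 is -80%. This expectation rests on a single prior instance of the change and on a different core, so it is held loosely.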

Compound 4, a percentage reported as activity, at one concentration (the size of the read-out at that concentration, not a potency): -64%
Compound 4: the middle estimate sits 31 percentage points below what was measured; the whole stated range lies below it.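

In this assay, for the compounds shown here, hydrogen in place of methoxy on an aromatic carbon gave a number 17 percentage points higher from compound 3 to compound 4 (beyond the scatter), so the change did not carry over from the core of compound 1 to the core of compound 3, neither in direction nor in size: the same change on two cores in this assay, a number 19 percentage points lower (beyond the scatter) from compound 1 to compound 2 and a number 17 percentage points higher (beyond the scatter) from compound 3 to compound 4, 36 percentage points apart, beyond the scatter of two such steps In these two pairs the outcome of the change therefore depends on the core that carries it, and a step read on one core gives no guide to the step on the other. What the pairs do not show is which feature of the two cores is responsible, and as the read-out was taken at a single concentration, the steps describe the size of the effect at that concentration and not a difference in potency.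

Going by these compounds alone, with only two cores carrying this change, it remains open how it would behave on a core with a carboxylic acid or a hydroxyl group in place of the amine of compound 1. Also open, going by these compounds, is whether an ethoxy group in place of the methoxy would follow either of the two steps.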